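A few compounds are considered here, and "the series" means these few. Any claim that something is new, unique, unknown or untested is made for them only; others in the source may bear on it.

Of the compounds shown here, three have been tested in an ADME assay on HeLa cells (Homo sapiens) for cytotoxicity, read by ATP content, with a stated time of 3 days; a lower number here means that less compound is tolerated, a higher number that more compound is tolerated. Compound 1 `CC(C)(C)n1c(=O)n(Cc2cc3cc(Cl)ccc3n2CCCS(C)(=O)=O)c2cnccc21` gives > 50000 nM in this assay, which is a limit of the assay rather than a number. Compound 2 `O=c1n(Cc2cc3cc(Cl)ccc3n2CCCCF)c2cnccc2n1C1CC1` likewise reaches only the limit, > 50000 nM. Compound 3 `CC(C)CCn1c(Cn2c(=O)n(C3CC3)c3ccncc32)nc2nc(Cl)ccc21` gives > 50000 nM, again a limit. So compound 3 stands where every compound tested so far stands, at the limit of > 50000 nM in this assay, at which 3 of the 3 values shown sit, with no number to compare against. For the measured compounds named here, no step between measured compounds can be read, since no two of them differ in only one place.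

Compound 4 `CC(C)(O)CCCn1c(Cn2c(=O)n(C3CC3)c3ccncc32)nc2nc(Cl)ccc21` is not yet measured. It differs from compound 3 by 2-hydroxy-2-methylpropyl in place of isopropyl on a saturated chain carbon, two bonds along the chain from an aromatic nitrogen. Because every value shown sits at the limit of > 50000 nM in this assay, at which 3 of the 3 values shown sit, the step from compound 3 to compound 4 in this assay is expected to be none beyond the scatter, and the most likely outcome is that compound 4 is also reported only as a limit. For compound 4 the expected value in this assay is 80000 nM, with a range from 40000 nM to 200000 nM. The expected step is a step that the limit leaves unreadable from compound 3 to compound 4, which stays within the usual scatter.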

Compound 4, half-maximal cytotoxic concentration: > 50000 nM
Compound 4: no number, only a limit; the forecaster's own chance of this, stated with the estimate: 85%; the middle value is on the limit's open side.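

For the compounds shown here, no step from compound 3 to compound 4 can be read in this assay because both results are limits rather than numbers: the limit of > 50000 nM in this assay, at which 4 of the 4 values shown sit. The compounds shown leave open what concentration harms these cells, and whether 2-hydroxy-2-methylpropyl in place of isopropyl alters it.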